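Compound 3 to compound 4: methoxy in place of methyl

A few compounds are considered here, and "the series" means these few. Any claim that something is new, unique, unknown or untested is made for them only; others in the source may bear on it.

Compound 1 `CNc1nc(-c2cc(OC)c(OC)c(OC)c2)c(-c2ccc(OC)cc2)s1`: 138 nM
Compound 2 `COc1cc(-c2nc(N(C)C)sc2-c2ccc(C)cc2)cc(OC)c1OC`: 3960 nM
Compound 3 `COc1cc(-c2nc(C)sc2-c2ccc(C)cc2)cc(OC)c1OC`: 1950 nM

All three compounds were tested in a functional assay on A549 cells (Homo sapiens) for antiproliferative activity, read by MTT assay, with a stated time of 72 h; on this read-out higher numbers stand for weaker inhibition and lower numbers for stronger inhibition. Compound 3, at 1950 nM, stands second highest of the three numbers. Only compound 2 gives a higher number, 3960 nM. Compound 1 gives 138 nM, the lowest of the three numbers.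

Compound 4 `COc1ccc(-c2sc(C)nc2-c2cc(OC)c(OC)c(OC)c2)cc1` has not yet been measured. It arises from compound 3 by a single change: methoxy in place of methyl on an aromatic carbon. This is methoxy in place of methyl on an aromatic carbon, para to a large group, turning 4-methylphenyl into 4-methoxyphenyl.

Among the compounds with values here, the only measured step, a 2.0-fold lower number from compound 2 to compound 3 (0.31 log units; beyond the scatter), was modest. It is a different change, methyl in place of dimethylamino, so it sets no direct size for this one. The better hint is compound 1, which already carries 4-methoxyphenyl and gives 138 nM. That compound also differs in another group, so its value can only suggest a direction. A clearly lower number is therefore expected in this assay, though with wide uncertainty. The expected step is a 4.9-fold lower number from compound 3 to compound 4 (0.69 log units; beyond the scatter). Compound 4 is estimated at 400 nM, with an expected range of 80 nM to 1800 nM.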

Compound 4, half-maximal inhibitory concentration: 2560 nM
Compound 4: the middle estimate sits 6.4-fold (0.81 log units) below what was measured; measured number above the stated range.
By their numbers in this assay, from the lowest: compound 1; then compounds 3, 4 and 2 (each within the scatter of the next, the first and the last beyond it).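

In this assay, methoxy in place of methyl on an aromatic carbon, para to a large group, gives a 1.3-fold higher number from compound 3 to compound 4 (0.12 log units; within the scatter), so with methyl on the shared core, 4-methylphenyl and 4-methoxyphenyl cannot be told apart. Within the data shown here, the low number of compound 1 therefore cannot be credited to 4-methoxyphenyl alone: with that group kept, methyl in place of methylamino gives a 19-fold higher number from compound 1 to compound 4 (1.27 log units; beyond the scatter), a large step that the earlier compounds could only hint at. Nothing measured here accounts for either step.

On these data alone, it remains open whether the change from 4-methylphenyl to 4-methoxyphenyl would stay within the scatter on a core carrying methylamino rather than methyl, since only the methyl-bearing pair reads this change directly. As far as these compounds go, it also remains open how far the low number of compound 1 would hold with an unsubstituted amine or a longer chain such as ethylamino in place of methylamino, or with ethoxy or chlorine in place of methoxy on the phenyl ring.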